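The compounds below may be only part of what the source reports. "The series", "measured", "known", "first", "only" and "open" are said of these compounds alone.

Compound 3 `C=CC1=C(C(=O)NCc2ccc(C)cc2)C(c2ccc(OC)c(OC)c2)OC1` stands at the edge of what is measured. In a functional assay on SW480 cells (Homo sapiens) for cytotoxicity, read by MTT assay, with a stated time of 24 h (a lower number here means a stronger inhibitor, a higher number a weaker inhibitor), compound 3 gives > 100000 nM, which is a limit of the assay and not a number. Compound 1 `C=CC1=C(C(=O)NCc2ccc(C)cc2)C(c2ccc(OC)cc2)OC1` gives 31700 nM in this assay. Compound 2 `C=CC1=C(C(=O)Nc2ccccc2)C(c2ccc(F)cc2)OC1` gives > 100000 nM, again a limit. The single step that connects two of these compounds, an at least 3.1-fold higher number from compound 1 to compound 3 (0.49 log units; beyond the scatter), is itself bounded by the limit of > 100000 nM in this assay, at which 2 of the 3 values shown sit.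

Compound 4 `C=CC1=C(C(=O)NC2CCCCC2)C(c2ccc(OC)c(OC)c2)OC1` differs from compound 3 by cyclohexyl in place of 4-methylbenzyl on an amide-type nitrogen. Among the measured compounds shown here, no measured step touches the amide-type nitrogen, so nothing here predicts the size or direction of the change; with compound 3 already at a limit, the value of compound 4 is estimated at 100000 nM, between 30000 nM and 300000 nM, a step of a number no higher from compound 3 to compound 4 (the limit leaves the size open).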

Compound 4, half-maximal inhibitory concentration: 19100 nM
Compound 4: middle estimate off by 5.2-fold (0.72 log units), on the high side, outside the stated range (below it).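

At the amide-type nitrogen, in this assay, cyclohexyl in place of 4-methylbenzyl gives an at least 5.2-fold lower number from compound 3 to compound 4 (0.71 log units; beyond the scatter). This is the first step shown at this position, and it shows that a change on this nitrogen can move the number towards a stronger inhibitor. The value of compound 3 is a limit and not a number, so the full size of the step stays open: the limit of > 100000 nM in this assay, at which 2 of the 4 values shown sit.

The compounds shown leave open whether the gain comes with the loss of the aromatic ring or with the change in the group's size. From the compounds shown here alone, what a straight hexyl chain or a benzyl group without the methyl would give on this nitrogen also remains open.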